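Removing the Aminomethyl Arm: Expected Lipophilicity Gain

The source may report more compounds than this note shows. Statements on the series, on what has been measured and on what is new or still open speak of the compounds shown alone.

For the measured compounds named here, compound 2 `NC[C@H](NC(=O)c1ccc(C#Cc2ccccc2)cc1)C(=O)NO` is one of two compounds measured in a physicochemical assay for lipophilicity; on this read-out higher numbers stand for higher lipophilicity and lower numbers for lower lipophilicity. In this assay compound 2 gives 2, the only outright number shown for this read-out. Compound 1 `CC(NC(=O)c1ccc(C#Cc2ccccc2)cc1)C(=O)NO` differs from it only by a group on an amide-type nitrogen. In this assay compound 1 reaches > 3, which is a limit of the assay rather than a number (the limit of > 3 in this assay, at which 1 of the 2 values shown sits). Going by the values given here, the step of a number at least 1.00 log units lower from compound 1 to compound 2 (beyond the scatter) is the one measured change that bears on the move to compound 3 `O=C(CNC(=O)c1ccc(C#Cc2ccccc2)cc1)NO`, where (hydrogen in place of aminomethyl on a saturated chain carbon bound to an amide-type nitrogen and a carbonyl carbon). Since that change removes the aminomethyl group altogether, the value is expected to climb again, and a rise of about a number 0.90 log units higher from compound 2 to compound 3 (beyond the scatter) in this assay is expected, with some chance that the assay again reports only a limit. For compound 3 the estimate in this assay is 2.9, within a range from 2.3 to 3.5.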

Compound 3, distribution coefficient: 3
The estimate for compound 3 lay 0.10 log units below the measured number, and the stated range covers the measured number.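

In this assay, hydrogen in place of aminomethyl on a saturated chain carbon bound to an amide-type nitrogen and a carbonyl carbon gives a number 1.00 log units higher from compound 2 to compound 3 (beyond the scatter), a modest step. For the compounds shown here, the earlier comparison with methyl had a limit at one end, so this is the first full number for the aminomethyl change here, and both methyl and hydrogen now read higher than aminomethyl. Hydrogen in place of methyl gives a number no higher from compound 1 to compound 3 (the limit leaves the size open). That step cannot be read, because the value of compound 1 is a limit of the assay: the limit of > 3 in this assay, at which 1 of the 3 values shown sits.

On these data alone, whether methyl and hydrogen differ at this position therefore stays open. Also open, as far as these compounds go, is whether the lower number belongs to aminomethyl alone or would also appear with hydroxymethyl, or with a longer chain ending in an amine or a carboxylic acid.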